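This account rests on a few compounds, and the source may have more. Where it says the series, first, only, none or still open, it means among the compounds named here.

Compound 2 `OC[C@H]1OC(n2cnc3c(-c4cc[nH]c4)ncnc32)[C@H](O)[C@@H]1O` gives 1030 nM in a functional assay on CCRF-CEM cells (Homo sapiens) for inhibition (on this read-out lower numbers stand for stronger inhibition and higher numbers for weaker inhibition), the higher of the two numbers recorded, although compound 1 `OC[C@H]1OC(n2cnc3c(-c4ccc(Cl)cc4)ncnc32)[C@H](O)[C@@H]1O`, giving 900 nM, lies within the scatter of it. Going by the values given here, the one step that bears here is a 1.1-fold higher number from compound 1 to compound 2 (0.06 log units; within the scatter), an exchange of one aromatic group for another on the same aromatic carbon. Compound 3 `Cc1cc(-c2ncnc3c2ncn3C2O[C@H](CO)[C@@H](O)[C@H]2O)on1` differs from compound 2 by 3-methyl-1,2-oxazol-5-yl in place of 1H-pyrrol-3-yl on an aromatic carbon. Because the earlier exchange on that carbon, a 1.1-fold higher number from compound 1 to compound 2 (0.06 log units; within the scatter), stayed within the scatter, compound 3 is expected to show no step beyond the scatter in this assay. Compound 3 is therefore estimated at 1000 nM, in the range 400 nM to 2500 nM. This estimate for compound 3 means an expected step of a 1.0-fold lower number from compound 2 to compound 3 (0.01 log units; within the scatter).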

Compound 3, half-maximal inhibitory concentration: "not active" (no number reported)
Nothing numeric was reported for compound 3; no gap can be computed for the estimate.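

Going by these compounds alone, compound 3 is recorded as "not active" in this assay with no number, and no step from compound 2 to it can be read. Nothing shown accounts for this result. The compounds shown leave open how far compound 3 actually lies from compound 2.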